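Phenyl for cyclopentyl on the amine nitrogen

This account rests on a few compounds, and the source may have more. Where it says the series, first, only, none or still open, it means among the compounds named here.

Compound 3 `O=C1C=C(NC2CCCC2)C(=O)c2c1nc1n2[C@H]2OC[C@@H](O)[C@H]2OC1` carries a cyclopentyl group on the amine nitrogen. In a functional assay on ECa-109 cells for inhibition, with ECa-109 cell line (Homo sapiens) as the target, read by sulforhodamine B assay (on this read-out lower numbers stand for stronger inhibition and higher numbers for weaker inhibition), compound 3 gives only a limit, > 16000 nM. Compound 1 `Cc1ccc(NC2=CC(=O)c3c(nc4n3[C@H]3OC[C@@H](O)[C@H]3OC4)C2=O)cc1` carries 4-methylphenyl on the same nitrogen, and in this assay compound 1 also gives a limit, > 4000 nM. Compound 2 `COc1ccccc1NC1=CC(=O)c2c(nc3n2[C@H]2OC[C@@H](O)[C@H]2OC3)C1=O` carries 2-methoxyphenyl, and in this assay compound 2 gives a limit, > 4000 nM. The step that the two limits leave unreadable from compound 1 to compound 2 cannot be read. Compound 4 `O=C1C=C(Nc2ccccc2)C(=O)c2c1nc1n2[C@H]2OC[C@@H](O)[C@H]2OC1` is the unmeasured member; its change from compound 3 is phenyl in place of cyclopentyl on an amine nitrogen. Among the compounds with values here, no measured step bears directly on this change: compounds 1 and 2 both sit at the limit of > 4000 nM in this assay, at which 2 of the 3 values shown sit, compound 3 sits at the limit of > 16000 nM in this assay, at which 1 of the 3 values shown sits, so every value shown is a limit and no size of step can be taken from them. The expectation is that compound 4 again sits at the reporting limit, and the step of an at least 2.0-fold lower number from compound 3 to compound 4 (0.30 log units; that floor lies within the scatter) is an expected step only, with no shift among the compounds above to anchor it. The estimate for compound 4 in this assay is 8000 nM, in the range 2500 nM to 30000 nM.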

Compound 4, half-maximal inhibitory concentration: 4970 nM
Estimate against measurement, compound 4: 1.6-fold (0.21 log units) above; the range from low to high includes it.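

In this assay, within the data shown here, compound 4 gives 4970 nM, the first value in this set that is a number and not a limit, so an amine nitrogen bearing plain phenyl yields a readable result. Phenyl in place of cyclopentyl gives an at least 3.2-fold lower number from compound 3 to compound 4 (0.50 log units; beyond the scatter), which is the first readable step here and shows that this change lowers the number beyond the scatter. On these data alone, the figure for compound 3 is a limit, so the true size of this step remains unknown and could be larger than printed.

Compounds 1 and 2 are reported only as limits, so their step cannot be read, and whether a substituent on the phenyl moves the number stays unresolved. Also open, as far as these compounds go, is how a benzyl group, a 4-chlorophenyl group or a longer alkyl chain on the same nitrogen would read.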